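A few compounds are considered here, and "the series" means these few. Any claim that something is new, unique, unknown or untested is made for them only; others in the source may bear on it.

Working notes on the series. Three compounds share one core and carry different groups on an oxygen next to a carbonyl group. Compound 1 `Cc1c(C(=O)OC(C)C(C)(C)C)c[nH]c1C(=O)Oc1cccnc1` gives 720 nM in an assay on CHO cells for inhibition of metabotropic glutamate receptor 1 (Rattus norvegicus); a higher number here means a weaker inhibitor, a lower number a stronger inhibitor. Compound 2 `CCCOC(=O)c1[nH]c(C(=O)OC)c(C(=O)OC(C)(C)C)c1C`, which also differs elsewhere from the other two, gives 3200 nM in this assay. Compound 3 `CCN1CCC(OC(=O)c2[nH]cc(C(=O)OC(C)C(C)(C)C)c2C)C1` gives 260 nM in this assay and stands at the lowest number of the three; the nearest is compound 1, the furthest is compound 2.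

Within the data shown here, the one single-change step so far, a 2.8-fold lower number from compound 1 to compound 3 (0.44 log units; beyond the scatter), came from putting 1-ethylpyrrolidin-3-yl in place of pyridin-3-yl on an oxygen next to a carbonyl group. Compound 4 `Cc1c(C(=O)OC(C)C(C)(C)C)c[nH]c1C(=O)OC(C)(C)C` has not yet been measured in this assay. Its change from compound 3: tert-butyl in place of 1-ethylpyrrolidin-3-yl on an oxygen next to a carbonyl group. This bears directly on the earlier step, since the group that brought the lower number is now removed and replaced by a group without ring or acceptor. Compound 2, which carries a plain alkyl group at the same oxygen, shows the highest number of the three, though it differs in more than one place. The expectation is therefore a step back upward, of a size comparable to the earlier one. For compound 4 the estimate in this assay is 1000 nM, ranging from 350 nM to 3000 nM, a step of a 3.8-fold higher number from compound 3 to compound 4 (0.59 log units; beyond the scatter).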

Compound 4, half-maximal inhibitory concentration: 17 nM
Estimate against measurement, compound 4: 59-fold (1.77 log units) above, outside the stated range (below it).
By their numbers in this assay, from the lowest: compound 4; then compound 3; then compound 1; then compound 2.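

In this assay, the group on an oxygen next to a carbonyl group matters far more than the earlier modest step, a 2.8-fold lower number from compound 1 to compound 3 (0.44 log units; beyond the scatter), could show: putting tert-butyl in place of 1-ethylpyrrolidin-3-yl gives a 15-fold lower number from compound 3 to compound 4 (1.18 log units; beyond the scatter), a large step that reverses the direction expected from that earlier result. Tert-butyl in place of pyridin-3-yl gives a 42-fold lower number from compound 1 to compound 4 (1.63 log units; beyond the scatter), so among the three compounds that differ only in this group, the one with no ring and no hydrogen-bond acceptor in it carries the lowest number, and neither the ring nor the nitrogen of the earlier groups is needed for a low number in this assay. Nothing at hand accounts for this order of the three groups.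

Still open, from the compounds shown here alone, is whether the low number belongs to tert-butyl itself or extends to other carbon-only groups at this oxygen, such as isopropyl, cyclopentyl or a longer chain like n-hexyl. An open-chain amine such as 2-(dimethylamino)ethyl at the same oxygen would show whether the higher number of compound 3 goes with the amine nitrogen or with the ring that carries it.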